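The source may hold more compounds than are shown below. What is called first, only, known or untested is meant among the compounds shown, and "the series" means these compounds.

Compound 3 `CCNS(=O)(=O)CCNc1nonc1/C(=N/O)Nc1ccc(F)c(Br)c1` gives 41 nM in an assay on HeLa cells for inhibition of Indoleamine 2,3-dioxygenase 1 (Homo sapiens), read by spectrophotometry, with a stated time of 24 h (on this read-out higher numbers stand for an effect only at larger amounts of compound and lower numbers for an effect already at smaller amounts), the lowest of the three numbers measured. Its neighbours are compound 1 `NS(=O)(=O)NNc1nonc1/C(=N/O)Nc1ccc(F)c(Br)c1` with 101 nM and compound 2 `O=S(=O)(CCNc1nonc1/C(=N/O)Nc1ccc(F)c(Br)c1)N1CCC1` with 143 nM. The step from compound 3 to compound 4 `CN(C)S(=O)(=O)CCCNc1nonc1/C(=N/O)Nc1ccc(F)c(Br)c1` is (dimethylsulfamoyl)methyl in place of ethylsulfamoyl on a saturated chain carbon, two bonds along the chain from a nitrogen on an aromatic ring. Going by the values given here, two measured steps bear on it: the change of the group on the sulfonyl sulfur, a 3.5-fold lower number from compound 2 to compound 3 (0.54 log units; beyond the scatter), and the change of the whole side chain, a 2.5-fold lower number from compound 1 to compound 3 (0.39 log units; beyond the scatter). Compound 4 shares with compound 2 the absence of a hydrogen-bond donor in the side chain and also lengthens the chain, so a modest rise in this assay is expected, with the estimated step being a 2.7-fold higher number from compound 3 to compound 4 (0.43 log units; beyond the scatter). Compound 4 is therefore expected to give about 110 nM, ranging from 40 nM to 300 nM.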

Compound 4, half-maximal effective concentration: 20 nM
Beside the measured number, compound 4's estimate is 5.5-fold (0.74 log units) above it, outside the stated range (below it).
By their numbers in this assay, from the lowest: compound 4; then compound 3; then compounds 1 and 2 (each within the scatter of the next).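

In this assay the change to (dimethylsulfamoyl)methyl on this saturated chain carbon gives a 2.1-fold lower number from compound 3 to compound 4 (0.31 log units; beyond the scatter) and removes the one hydrogen-bond donor of ethylsulfamoyl, so a low number here does not depend on that donor. Compound 4 also sits clearly under the other two, with a 7.2-fold lower number from compound 2 to compound 4 (0.85 log units; beyond the scatter) and a 5.1-fold lower number from compound 1 to compound 4 (0.70 log units; beyond the scatter) as the steps. Nothing at hand accounts for these steps. On these data alone, the dimethyl group and the added chain carbon change together, so their separate shares stay open. A 2-(dimethylsulfamoyl)ethyl or 4-(dimethylsulfamoyl)butyl chain would bear on that question.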